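This account rests on a few compounds, and the source may have more. Where it says the series, first, only, none or still open, it means among the compounds named here.

Measured in a functional assay on MCF7 cells (Homo sapiens) for cytotoxicity, read by MTT assay, with a stated time of 24 h; a higher number here means a weaker inhibitor, a lower number a stronger inhibitor:
compound 1 `Cn1nc(-c2nnc(SCc3cccc(Cl)c3Cl)o2)cc1-c1ccc(C(F)(F)F)cc1` gives 32200 nM
compound 2 `Cn1nc(-c2nnc(SCc3ccc(Cl)cc3F)o2)cc1-c1ccc(C(F)(F)F)cc1` gives 18200 nM
compound 3 `Cn1nc(-c2ccc(C(F)(F)F)cc2)cc1-c1nnc(SCc2c(F)cccc2F)o1` gives 46200 nM

Compound 3 holds the highest of the three numbers; its gap to compound 1 lies within the scatter, its gap to compound 2 beyond it. Compound 4 `Cn1nc(-c2ccc(C(F)(F)F)cc2)cc1-c1nnc(SCc2cccc([N+](=O)[O-])c2)o1` differs from compound 3 by 3-nitrophenyl in place of 2,6-difluorophenyl on a saturated chain carbon bound to a sulfur. For the measured compounds named here, the only measured step at the same place, a change of the halogen pattern of the phenyl on the saturated chain carbon bound to a sulfur, is a 1.8-fold lower number from compound 1 to compound 2 (0.25 log units; within the scatter) and stayed within the scatter. Going by the values given here, no measured step tests a nitro group, so the step expected in this assay is small, a 1.3-fold lower number from compound 3 to compound 4 (0.12 log units; within the scatter), with no direction beyond the scatter. Compound 4 is estimated at 35000 nM, range 15000 nM to 80000 nM.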

Compound 4, half-maximal inhibitory concentration: > 100000 nM
Compound 4: a limit, no number; the forecaster's own chance of this, stated with the estimate: 5%; middle value at least 2.8-fold (0.45 log units) away from the limit.
By their numbers in this assay, from the lowest: compounds 2, 1 and 3 (each within the scatter of the next, the first and the last beyond it). At a limit, above all of these: compound 4.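

In this assay compound 4 gives > 100000 nM, which is a limit and not a number: the limit of > 100000 nM in this assay, at which 1 of the 4 values shown sits. Replacing 2,6-difluorophenyl with 3-nitrophenyl on a saturated chain carbon bound to a sulfur gives an at least 2.1-fold higher number from compound 3 to compound 4 (0.33 log units; beyond the scatter), whereas the earlier step at this place, a 1.8-fold lower number from compound 1 to compound 2 (0.25 log units; within the scatter), stayed within the scatter. This position can therefore carry a change that moves the number beyond the scatter, and here that change is towards a weaker inhibitor.

On these data alone, the full size of the step stays open. So does whether an amine or a carboxylic acid on this phenyl would give a measurable number.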